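Side-chain change from compound 2 to compound 3

This account rests on a few compounds, and the source may have more. Where it says the series, first, only, none or still open, it means among the compounds named here.

Measured so far:
- compound 1 `Cn1cc(-c2cnc3ccnc(NC(=O)c4cccnc4)c3c2)cn1`: > 50000 nM
- compound 2 `Cn1cc(-c2cnc3ccnc(NCC4CC4)c3c2)cn1`: 8900 nM

For the measured compounds named here, in a functional assay on A549 cells (Homo sapiens) for antiproliferative activity, read by MTT assay, with a stated time of 48 h (on this read-out higher numbers stand for weaker inhibition and lower numbers for stronger inhibition), compound 2 gives 8900 nM, the only actual number so far. The entry for compound 1, > 50000 nM, is a limit of the assay.

Compound 3 `COc1ccc(CNc2nccc3ncc(-c4cnn(C)c4)cc23)cc1` keeps the shared core and differs from compound 2 at the side chain: 4-methoxyphenyl in place of cyclopropyl on a saturated chain carbon bound to a nitrogen on an aromatic ring. This places 4-methoxyphenyl in place of cyclopropyl on a saturated chain carbon bound to a nitrogen on an aromatic ring.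

Going by the values given here, the only measured step, an at least 5.6-fold lower number from compound 1 to compound 2 (0.74 log units; beyond the scatter), also changed the group on that nitrogen, so it bears on this change only loosely. It shows that the read-out can respond to a change there, but it does not test this exchange. A modest step is therefore expected, with no firm direction, and a result within the scatter would not be surprising. The expected step is a 1.3-fold lower number from compound 2 to compound 3 (0.10 log units; within the scatter). For compound 3 the estimated value is 7000 nM, with an expected range of 2000 nM to 30000 nM.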

Compound 3, half-maximal inhibitory concentration: > 50000 nM
Compound 3: no number, only a limit (the forecaster's own chance of this, stated with the estimate: 12%); middle value at least 7.1-fold (0.85 log units) from the limit.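

In this assay, 4-methoxyphenyl in place of cyclopropyl on the saturated chain carbon gives an at least 5.6-fold higher number from compound 2 to compound 3 (0.74 log units; beyond the scatter), so the read-out responds to the group carried on that chain carbon and not only to the whole group on the nitrogen. The entry for compound 3, > 50000 nM, is a limit of the assay. The full size of the step cannot be read because the values stop at that limit: the limit of > 50000 nM in this assay, at which 2 of the 3 values shown sit.

As far as these compounds go, whether the change follows from the aromatic ring itself or from its methoxy group stays open, as does the reading of a plain phenyl, a cyclobutyl or a longer alkyl chain on that carbon. For the compounds shown here, also open is whether any group there gives a lower number than compound 2, at 8900 nM, the only actual number in the set.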